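From 1-benzofuran-2-yl to iodo on the shared core

The compounds below may be only part of what the source reports. "The series", "measured", "known", "first", "only" and "open" are said of these compounds alone.

In a functional assay on CEM-DNR-bulk cells (Homo sapiens), read by MTT assay, with a stated time of 72 h (on this read-out lower numbers stand for stronger inhibition and higher numbers for weaker inhibition), compound 1 `CNc1ncnc2c1c(-c1cc3ccccc3o1)cn2[C@@H]1O[C@H](CO)[C@@H](O)[C@H]1O` gives > 20000 nM as a limit only. Compound 2 `CN(C)c1ncnc2c1c(-c1cc3ccccc3o1)cn2[C@@H]1O[C@H](CO)[C@@H](O)[C@H]1O` gives > 20000 nM as a limit too. Compound 3 `Cc1ncnc2c1c(-c1cc3ccccc3o1)cn2[C@@H]1O[C@H](CO)[C@@H](O)[C@H]1O` gives > 20000 nM as a limit as well, and the limit of > 20000 nM in this assay, at which 3 of the 3 values shown sit, covers the whole set. Next comes compound 4 `Cc1ncnc2c1c(I)cn2[C@@H]1O[C@H](CO)[C@@H](O)[C@H]1O` with the change iodo in place of 1-benzofuran-2-yl on an aromatic carbon in view. The measured steps are a step that the two limits leave unreadable from compound 1 to compound 2 and a step that the two limits leave unreadable from compound 1 to compound 3 and a step that the two limits leave unreadable from compound 2 to compound 3 and none of them touches the 1-benzofuran-2-yl group, so they give no size to carry over. An expected at least 6.6-fold lower number from compound 3 to compound 4 (0.82 log units; beyond the scatter) toward stronger inhibition in this assay is therefore a loose estimate. For compound 4 the estimate is 3000 nM with an expected range of 150 nM to 20000 nM and a real chance of another limit.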

Compound 4, half-maximal inhibitory concentration: 12600 nM
For compound 4 the middle estimate is 4.2-fold (0.62 log units) below the measured one, within the range that was stated.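

Iodo in place of 1-benzofuran-2-yl on this aromatic carbon gives the only compound shown with a number rather than a limit in this assay, with an at least 1.5-fold lower number from compound 3 to compound 4 (0.20 log units; that floor lies within the scatter). Compound 3 carries only a limit, so the step has a floor and no true size. The steps among compound 1, compound 2 and compound 3 cannot be read: the limit of > 20000 nM in this assay, at which 3 of the 4 values shown sit.

On these data alone, what chloro or phenyl would give on this carbon stays open. Also open, as far as these compounds go, is whether methylamino or dimethylamino in place of methyl keeps a measurable number alongside iodo.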